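From pyrrolidin-1-yl to methylsulfanyl on the shared core

This account rests on a few compounds, and the source may have more. Where it says the series, first, only, none or still open, it means among the compounds named here.

Values in an ADME assay on HFF cells (Homo sapiens) for cytotoxicity, with a stated time of 8 days (on this read-out higher numbers stand for lower toxicity in this test and lower numbers for higher toxicity in this test), follow, both of them limits:
Compound 1 `C=CCOc1nc(N)nc2c1ncn2/C=C1/CC1(CO)CO` reads > 300000 nM as a limit
Compound 2 `Nc1nc(N2CCCC2)c2ncn(/C=C3/CC3(CO)CO)c2n1` reads > 300000 nM as a limit

Compound 2 stands at a limit and not at a number, and the limit of > 300000 nM in this assay, at which 2 of the 2 values shown sit, shows that the other measured compound stands there too. Compound 3 `CSc1nc(N)nc2c1ncn2/C=C1/CC1(CO)CO` carries methylsulfanyl in place of pyrrolidin-1-yl on an aromatic carbon and has not yet been measured. Going by the values given here, the one measured step that bears on this change is a step that the two limits leave unreadable from compound 1 to compound 2 and it involves pyrrolidin-1-yl in place of allyloxy on an aromatic carbon. It offers no size to carry over, so the expectation rests on both measured compounds sitting at the limit. No change beyond the usual scatter is expected in this assay and the expected step is an at least 1.2-fold lower number from compound 2 to compound 3 (0.07 log units; that floor lies within the scatter) in either reading. Compound 3 is estimated at 250000 nM (expected range 80000 nM to 300000 nM) and may well be reported only as a limit.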

Compound 3, half-maximal cytotoxic concentration: > 300000 nM
Compound 3: only a limit was reported (the forecaster's own chance of this, stated with the estimate: 75%); middle value at least 1.2-fold (0.07 log units) from the limit.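

In this assay, no step can be read among compound 1, compound 2 and compound 3, since all of them stop at the same limit: the limit of > 300000 nM in this assay, at which 3 of the 3 values shown sit. The compounds shown leave open how allyloxy, pyrrolidin-1-yl and methylsulfanyl compare on the shared core, as none yields a number.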